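A few compounds are considered here, and "the series" means these few. Any claim that something is new, unique, unknown or untested is made for them only; others in the source may bear on it.

Measured in a functional assay on the whole organism (strain Wistar) for inhibition, with Rattus norvegicus as the target, read by paw edema, with stated times of 30 min and 3 h, at a dose of 100 mg/kg by the oral route; on this read-out higher numbers stand for more inhibition at the one dose given (going by the name of the read-out) and lower numbers for less inhibition:
compound 1, `COc1cc(C(=O)N(C)C)nn1-c1ccccc1`: 47.5%
compound 2, `CCCCNC(=O)c1cc(OC)n(-c2ccccc2)n1`: 20.6%
compound 3, `CCCCOc1cc(C(=O)NCC)nn1-c1ccccc1`: 0%

Compound 3 stands lowest of the three in this assay, with compound 2 nearest and compound 1 furthest; both gaps are beyond the scatter. For the measured compounds named here, the only single-point step measured so far is on the carbonyl substituent: a number 26.9 percentage points lower from compound 1 to compound 2 (beyond the scatter). Going by the values given here, compounds 2 and 3 differ at two places at once, so their values show only that compound 3 is lower.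

Compound 4, `CCCCOc1cc(C(=O)NCCCN(C)C)nn1-c1ccccc1`, has not yet been tested. It differs from compound 3 by (dimethylamino)methyl in place of hydrogen on a saturated chain carbon, two bonds along the chain from an amide-type nitrogen. Among the compounds with values here, this is again a change on the amide side, as in the step from compound 1 to compound 2, but the group entering here is of a different kind, and nothing measured so far carries a (dimethylamino)methyl group. Within the data shown here, the one step on this side of the molecule was modest in size, so a change of similar order in this assay is plausible in either direction, with no firm basis for a direction. Since compound 3 already reports no inhibition, the estimate for compound 4 is set close to that value, with the range opening upward: 10%, from 0% to 35%, which means an expected step of a number 10 percentage points higher from compound 3 to compound 4 (within the scatter).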

Compound 4, a percentage reported as inhibition, in the whole organism at one dose (the size of the read-out at that dose, not a potency): 29.8%
The estimate for compound 4 lay 19.8 percentage points below the measured number; measured number inside the range.
By their numbers in this assay, from the lowest: compound 3; then compounds 2 and 4 (each within the scatter of the next); then compound 1.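

In this assay, the ethylamino to (3-(dimethylamino)propyl)amino change gives a number 29.8 percentage points higher from compound 3 to compound 4 (beyond the scatter), so this saturated chain carbon is a place where substitution can move the read-out upward from a compound with no reported inhibition. For the compounds shown here, the only earlier step on the amide side, a number 26.9 percentage points lower from compound 1 to compound 2 (beyond the scatter), ran downward with butylamino in place of dimethylamino, so these two steps, each on its own background, show that changes on this side can move the number in either direction. No measurement at hand bears on the reason for the rise.

Going by these compounds, it remains open whether the rise goes with the dimethylamino group or with the carbon chain alone: a plain propyl group or a 3-(piperidinyl)propyl group in place of the 3-(dimethylamino)propyl group would help separate the two. Also open, on these data alone, is whether the 3-(dimethylamino)propyl group would give a step of this kind on the core of compound 1, where the amide side carries dimethylamino.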